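The source may report more compounds than this note shows. Statements on the series, on what has been measured and on what is new or still open speak of the compounds shown alone.

Measured in an ADME assay on microsomes from liver (Rattus norvegicus) for metabolic stability, using NADPH; a lower number here means slower removal, a higher number faster removal of the compound:

Compound 1 `CC(O)(CNC(=O)c1ncc(C(F)(F)F)cc1N)C(F)(F)F`: < 0.025 mL/min/kg, a limit of the assay
Compound 2 `Cc1nc(C(=O)NCC(C)(O)C(F)(F)F)c(N)cc1C(F)(F)F`: 0.0738 mL/min/kg

For the measured compounds named here, compound 2 holds the only actual number so far. The value for compound 1 is a limit of the assay. The next compound, compound 3 `CCc1nc(C(=O)NCC(C)(O)C(F)(F)F)c(N)cc1C(F)(F)F`, differs from compound 2 by methyl in place of hydrogen on a saturated chain carbon bound to an aromatic carbon, so that methyl becomes ethyl.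

Going by the values given here, one measured step bears on this change: an at least 2.9-fold higher number from compound 1 to compound 2 (0.47 log units; beyond the scatter), where methyl took the place of hydrogen on an aromatic carbon. That step also added a single carbon, and it raised the number beyond the scatter. Among the compounds with values here, it happened at a different kind of atom, however, and it is the only such step available, so it offers only a loose guide to direction. A small further rise in this assay is therefore expected, one that may not clear the scatter. The expected change is a 1.5-fold higher number from compound 2 to compound 3 (0.17 log units; within the scatter). The estimate for compound 3 is 0.11 mL/min/kg, with an expected range from 0.05 mL/min/kg to 0.28 mL/min/kg.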

Compound 3, clearance: 0.0856 mL/min/kg
Estimate against measurement, compound 3: 1.3-fold (0.11 log units) above; measured number inside the range.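

In this assay, the change from methyl to ethyl on a saturated chain carbon bound to an aromatic carbon gives a 1.2-fold higher number from compound 2 to compound 3 (0.06 log units; within the scatter), so compound 2 and compound 3 cannot be told apart here, whereas the earlier added carbon, placed directly on the aromatic carbon, gave a step beyond the scatter. Measured against hydrogen on the aromatic carbon, ethyl gives an at least 3.4-fold higher number from compound 1 to compound 3 (0.53 log units; beyond the scatter), and this stands beyond the scatter just as an at least 2.9-fold higher number from compound 1 to compound 2 (0.47 log units; beyond the scatter) does, so the step away from hydrogen holds for both groups. The value for compound 1 is a limit of the assay, which leaves the full size of both of these steps unknown: the limit of < 0.025 mL/min/kg in this assay, at which 1 of the 3 values shown sits.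

The compounds shown leave open whether a longer chain such as propyl, a branched isopropyl or a cyclopropyl ring at this place would also stay within the scatter of methyl and ethyl. For the compounds shown here, they also leave open how a methoxy group or an amine there would read in this assay, since only two alkyl groups at this place carry actual numbers.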